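The source may report more compounds than this note shows. Statements on the series, on what has been measured and on what is new or still open speak of the compounds shown alone.

Measured compounds:
- Compound 1, `COc1cccc(/C=C2\CCC/C(=C\c3ccc(Cl)cc3)C2=O)c1OC`: 18600 nM
- Compound 2, `COc1ccc(/C=C2\CCC/C(=C\c3ccc(Br)cc3)C2=O)cc1OC`: 13100 nM

Both were tested in an ADME assay on NHDF cells (Homo sapiens) for cytotoxicity, read by MTT assay, with a stated time of 72 h; a higher number here means a weaker inhibitor, a lower number a stronger inhibitor. Compound 1 gives 18600 nM and compound 2 gives 13100 nM in this assay; the two numbers lie within the scatter of each other, so compound 2 cannot be set apart from compound 1 on these data. Compound 3, `COc1ccc(/C=C2\CCC/C(=C\c3ccc(O)c(O)c3)C2=O)cc1OC`, has not yet been measured in this assay. It differs from compound 2 in one place: 3,4-dihydroxyphenyl in place of 4-bromophenyl on a double-bonded chain carbon bound to a double-bonded ring carbon. Among the measured compounds shown here, no step between two measured compounds is available for this kind of change, so there is nothing to lean on beyond the two values already seen. With so little to go on, the step from compound 2 to compound 3 is expected to be small, possibly none beyond the scatter, and if anything toward a higher number: a 1.4-fold higher number from compound 2 to compound 3 (0.14 log units; within the scatter). Compound 3 is therefore estimated at 18000 nM in this assay, with a range from 7000 nM to 45000 nM.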

Compound 3, half-maximal inhibitory concentration: 25200 nM
For compound 3 the middle estimate is 1.4-fold (0.15 log units) below the measured one; the measured number falls inside the stated range.
By their numbers in this assay, from the lowest: compounds 2, 1 and 3 (each within the scatter of the next).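

In this assay, putting 3,4-dihydroxyphenyl in place of 4-bromophenyl on a double-bonded chain carbon bound to a double-bonded ring carbon gives a 1.9-fold higher number from compound 2 to compound 3 (0.28 log units; within the scatter). Among the compounds shown here, this is the first comparison here between two compounds that differ in one place, and it shows that this position can take a very different ring substituent, with hydroxyl groups and hydrogen-bond donors entering and bromine leaving, without a step beyond the scatter. Nothing measured here bears on the reason for this result.

Still open, on these data alone, is whether a simple 4-hydroxyphenyl, or a phenyl ring carrying an amine or a carboxylic acid, would also stay within the scatter at this position. As far as these compounds go, it is also open whether any group at this position can produce a step beyond the scatter.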